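This account rests on a few compounds, and the source may have more. Where it says the series, first, only, none or still open, it means among the compounds named here.

Going by the values given here, in an ADME assay on MT4 cells (Homo sapiens) for cytotoxicity, read by MTT assay (a lower number here means that less compound is tolerated, a higher number that more compound is tolerated), only two compounds with a shared core have numbers so far. Compound 1 (`O=C1c2ccccc2C(=O)N1CCOC(=S)N(C(=O)c1cccc([N+](=O)[O-])c1)c1ccc(Cl)cc1`) gives 18000 nM and compound 2 (`O=C1c2ccccc2C(=O)N1CCOC(=S)N(C(=O)c1cccc(Cl)c1Cl)c1ccc(Cl)cc1`) gives 54000 nM as the higher of the two, so compound 2 is the better tolerated of this pair. Compound 3 (`O=C1c2ccccc2C(=O)N1CCOC(=S)N(C(=O)c1c(Cl)cccc1Cl)c1ccc(Cl)cc1`) is made of the same atoms as compound 2 but joined differently, with 2,6-dichlorophenyl in place of 2,3-dichlorophenyl on a carbonyl carbon. Among the compounds with values here, one measured step bears on this change. It is a 3.0-fold higher number from compound 1 to compound 2 (0.48 log units; beyond the scatter) with 2,3-dichlorophenyl in place of 3-nitrophenyl on a carbonyl carbon, a modest move beyond the scatter. Within the data shown here, no measured pair shows what moving a chlorine does here. Among the measured compounds shown here, with a 3.0-fold higher number from compound 1 to compound 2 (0.48 log units; beyond the scatter) as the only guide, and that step a swap of different atoms, no step beyond the scatter is expected in this assay in either direction. The expected change is a 1.2-fold lower number from compound 2 to compound 3 (0.08 log units; within the scatter) and so lies within the scatter. For compound 3 the estimated value is 45000 nM within a range of 18000 nM to 100000 nM for repeated measurements.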

Compound 3, half-maximal cytotoxic concentration: 20000 nM
Estimate against measurement, compound 3: 2.3-fold (0.35 log units) above; low and high end bracket the measured number.
By their numbers in this assay, from the lowest: compounds 1 and 3 (each within the scatter of the next); then compound 2.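

In this assay the arrangement of the two chlorines on this ring matters, even though the ring stays on the same carbonyl carbon and the atom counts do not change: going from 2,3-dichlorophenyl to 2,6-dichlorophenyl gives a 2.7-fold lower number from compound 2 to compound 3 (0.43 log units; beyond the scatter) and so cancels the gain seen earlier in a 3.0-fold higher number from compound 1 to compound 2 (0.48 log units; beyond the scatter). The earlier pair could not show this, since it swapped different atoms, whereas here the group that leaves and the group that enters have the same composition, and only the way they are joined separates them. The third comparison (a 1.1-fold higher number from compound 1 to compound 3 (0.05 log units; within the scatter)) leaves 3-nitrophenyl and 2,6-dichlorophenyl indistinguishable, so two chlorines alone do not give the higher number, and compound 3 goes against any rule that dichlorophenyl groups are better tolerated than 3-nitrophenyl.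

Nothing available explains why the arrangement of the chlorines changes the number. On these data alone, it also remains open whether compound 2 owes its standing to both chlorines together, which a 2-chlorophenyl or 3-chlorophenyl group could test, and how a ring carrying an amine or a carboxylic acid would behave at this position.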